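The source may hold more compounds than are shown below. What is called first, only, known or untested is meant among the compounds shown, and "the series" means these compounds.

Compound 2 `COc1cc(C2=NOC(COc3ccc(-c4nnnn4-c4cc(OC)c(OC)c(OC)c4)cc3N)C2)cc(OC)c1OC` gives 2060 nM in a functional assay on A549 cells (Homo sapiens) for cytotoxicity, read by MTT assay, with a stated time of 48 h (a higher number here means a weaker inhibitor, a lower number a stronger inhibitor), the second highest of the three numbers recorded, between compound 1 `COc1ccc(C2=NOC(COc3ccc(-c4nnnn4-c4cc(OC)c(OC)c(OC)c4)cc3N)C2)cc1N` with 2080 nM and compound 3 `COc1cc(-n2nnnc2-c2ccc(OCC3CC(c4ccc(OC)c(OC)c4OC)=NO3)c(N)c2)cc(OC)c1OC` with 2030 nM; all three lie within the scatter of one another. Compound 4 `COc1cc(-n2nnnc2-c2ccc(OCC3CC(c4cccc(Cl)c4)=NO3)c(N)c2)cc(OC)c1OC` differs from compound 2 at the group on the carbon with a double bond to nitrogen: 3-chlorophenyl in place of 3,4,5-trimethoxyphenyl on a carbon with a double bond to nitrogen. Within the data shown here, two measured steps bear on this place. The step of a 1.0-fold lower number from compound 1 to compound 2 (0.00 log units; within the scatter) and the step of a 1.0-fold lower number from compound 2 to compound 3 (0.01 log units; within the scatter) both exchanged the group at this place without moving the number beyond the scatter. Compound 4 is therefore expected to show no step beyond the scatter, a 1.0-fold lower number from compound 2 to compound 4 (0.01 log units; within the scatter). The estimate for compound 4 in this assay is 2000 nM, with a range from 900 nM to 4500 nM.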

Compound 4, half-maximal inhibitory concentration: 1340 nM
Estimate against measurement, compound 4: 1.5-fold (0.17 log units) above, and the stated range covers the measured number.
By their numbers in this assay, from the lowest: compounds 4, 3, 2 and 1 (each within the scatter of the next).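

Every earlier group at this place in this assay carried a methoxy group, whereas 3-chlorophenyl carries none and is the smaller group. Even so, the number stays close across this change: the steps of a 1.5-fold lower number from compound 2 to compound 4 (0.19 log units; within the scatter), a 1.5-fold lower number from compound 3 to compound 4 (0.18 log units; within the scatter) and a 1.6-fold lower number from compound 1 to compound 4 (0.19 log units; within the scatter) all remain within the scatter. No evidence on the reason for this is available. Going by these compounds, it remains open whether a carboxylic acid, a cyclohexyl ring or a plain phenyl at this place would also stay within the scatter, and whether a change elsewhere on the shared core would go beyond it.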